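Sulfonyl nitrogen substitution in the trifluoromethyl hydroxyamide series

The compounds below may be only part of what the source reports. "The series", "measured", "known", "first", "only" and "open" are said of these compounds alone.

Measured so far:
compound 1, `CCN(CC)C(=O)c1ccc(NC(=O)C(C)(O)C(F)(F)F)cc1`: > 30000 nM
compound 2, `CCC(C)N(C(C)CC)S(=O)(=O)c1ccc(NC(=O)C(C)(O)C(F)(F)F)cc1`: > 30000 nM
compound 3, `CC(O)(C(=O)Nc1ccc(S(N)(=O)=O)cc1)C(F)(F)F`: 12800 nM

In an assay on a protein complex (Cavia porcellus) with sulfonylurea receptors; K-ATP channels (Homo sapiens) as the target (on this read-out higher numbers stand for weaker inhibition and lower numbers for stronger inhibition), compound 1 reaches only the limit of the assay, > 30000 nM. Compound 2 likewise gives only a limit in this assay, > 30000 nM. Going by the values given here, compound 3 is the one compound of the three with a measured number in this assay, 12800 nM. Both steps to it are at least modest: an at least 2.3-fold lower number from compound 1 to compound 3 (0.36 log units; beyond the scatter) and an at least 2.3-fold lower number from compound 2 to compound 3 (0.36 log units; beyond the scatter), their size bounded by the limit of > 30000 nM in this assay, at which 2 of the 3 values shown sit.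

Compound 4, `CN(C)S(=O)(=O)c1ccc(NC(=O)C(C)(O)C(F)(F)F)cc1`, is yet to be measured. It differs from compound 3 in one place: dimethylamino in place of amino on a sulfonyl sulfur. The step from compound 2 to compound 3 bears on this, since it also removes alkyl groups from the sulfonyl nitrogen; the dimethylamino of compound 4 sits between the amino of compound 3 and the bis(sec-butyl)amino of compound 2. A step in the weaker direction is therefore expected for compound 4, a 2.3-fold higher number from compound 3 to compound 4 (0.37 log units; beyond the scatter), with a real chance of a limit. The estimate for compound 4 in this assay is 30000 nM, within 10000 nM to 100000 nM.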

Compound 4, half-maximal inhibitory concentration: 480 nM
Estimate against measurement, compound 4: 63-fold (1.80 log units) above; measured number below the stated range.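

The sulfonyl nitrogen does not follow a simple trend with alkyl size in this assay: a 27-fold lower number from compound 3 to compound 4 (1.43 log units; beyond the scatter), and an at least 62-fold lower number from compound 2 to compound 4 (1.79 log units; beyond the scatter), so among these three groups the small dialkyl one gives the lowest number, with both amino and bis(sec-butyl)amino on the sulfonyl sulfur weaker. Changing the aromatic substituent now also matters far more than the earlier sulfamoyl comparison suggested, with an at least 62-fold lower number from compound 1 to compound 4 (1.79 log units; beyond the scatter) set against an at least 2.3-fold lower number from compound 1 to compound 3 (0.36 log units; beyond the scatter). The steps from compound 1 and compound 2 are bounded, not exact: the limit of > 30000 nM in this assay, at which 2 of the 4 values shown sit.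

Going by these compounds, whether methylamino or diethylamino on the sulfonyl sulfur would keep this gain remains open, so the width of the favourable range is undefined. These compounds also cannot tell what sets dimethylamino apart, or whether the gain survives a change to the trifluoromethyl hydroxyamide that all of them share.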